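Swapping a pyridine for a benzene on an ether-linked tail

This account rests on a few compounds, and the source may have more. Where it says the series, first, only, none or still open, it means among the compounds named here.

Measured compounds:
`O=C1N=C(O)S/C1=C\c1ccc(OCCc2ccccn2)cc1Cl` compound 1, 8920 nM
`O=C1NC(=O)/C(=C/c2ccc(OCCOC3CCCCC3)c(Cl)c2)S1` compound 2, 20 nM

In an assay for inhibition of 15-hydroxyprostaglandin dehydrogenase [NAD(+)] (Homo sapiens), read by fluorescence and spectrophotometry (a lower number here means a stronger inhibitor, a higher number a weaker inhibitor), compound 1 gives 8920 nM, the highest of the two numbers recorded. Its nearest neighbour is compound 2, which in this assay gives 20 nM, a gap that lies well beyond the scatter; the two compounds differ in several places at once, so the gap cannot be assigned to any single change.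

Compound 3, `O=C1N=C(O)S/C1=C\c1ccc(OCCc2ccccc2)cc1Cl`, has not yet been measured in this assay. It differs from compound 1 in one place: phenyl in place of pyridin-2-yl on a saturated chain carbon, two bonds along the chain from an oxygen on an aromatic ring. Going by the values given here, no step between measured compounds isolates this change, so the direction is uncertain. A small step from compound 1 to compound 3 is expected, within or just beyond the scatter, and the step of a 2.0-fold lower number from compound 1 to compound 3 (0.30 log units; within the scatter) is estimated to be a slight decrease. Compound 3 is expected to give 4500 nM, with a range from 1000 nM to 20000 nM.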

Compound 3, half-maximal inhibitory concentration: 178 nM
Estimate against measurement, compound 3: 25-fold (1.40 log units) above; the whole stated range lies above it.
By their numbers in this assay, from the lowest: compound 2; then compound 3; then compound 1.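

In this assay, going by these compounds alone, putting phenyl in place of pyridin-2-yl gives a 50-fold lower number from compound 1 to compound 3 (1.70 log units; beyond the scatter), the first comparison here that isolates a single change. It shows that this place on the tail, on a saturated chain carbon two bonds along the chain from an oxygen on an aromatic ring, responds strongly to the ring it carries, even though the two rings match in size and differ only in a carbon standing for the ring nitrogen. Nothing available explains why this exchange has so large an effect.

The compounds shown leave open whether the nitrogen would matter as much elsewhere in the ring, as in pyridin-3-yl or pyridin-4-yl. They also leave open whether a substituted phenyl, such as 4-chlorophenyl or 4-methoxyphenyl, or a longer chain would lower the number further.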